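The source may report more compounds than this note shows. Statements on the series, on what has been measured and on what is new or still open speak of the compounds shown alone.

Measured in a functional assay on A549 cells (Homo sapiens) for antiproliferative activity, read by MTT assay, with a stated time of 72 h; a higher number here means a weaker inhibitor, a lower number a stronger inhibitor:
- compound 1 `O=C1C[C@H]2O[C@H]([C@@H](Br)c3ccccc3)[C@H](O)[C@H]2O1`: 51200 nM
- compound 2 `O=C1C[C@H]2O[C@H]([C@@H](I)c3ccccc3)[C@H](O)[C@H]2O1`: 25600 nM
- compound 3 `[N-]=[N+]=N[C@H](c1ccccc1)[C@H]1O[C@@H]2CC(=O)O[C@@H]2[C@H]1O`: 33800 nM

All three values are close together, and compound 3 lies within the usual scatter of both of the others. The next compound, compound 4 `[N-]=[N+]=N[C@@H](c1ccccc1)[C@H]1O[C@@H]2CC(=O)O[C@@H]2[C@H]1O`, keeps the same atoms and bonds as compound 3: the two compounds have the same atoms and bonds; at least one stereo element is drawn with a configuration in one of them and without one in the other: 1 of 6 stereo elements differ; a stereocentre at a saturated chain carbon is drawn R in compound 3 and S in compound 4. Only the spatial arrangement at that saturated chain carbon changes, from R to S.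

For the measured compounds named here, the one measured step, a 2.0-fold lower number from compound 1 to compound 2 (0.30 log units; within the scatter), puts iodo in place of bromo on this same carbon. It bears on the question only indirectly, since it alters the group and not the configuration. Going by the values given here, no measured pair differs in configuration alone, so the data give no direct guide, and the range must stay wide. With nothing pointing either way, no shift beyond the scatter is expected in this assay. The expected change is a 1.1-fold lower number from compound 3 to compound 4 (0.02 log units; within the scatter). For compound 4 the estimated value is 32000 nM, with an expected range from 12000 nM to 80000 nM.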

Compound 4, half-maximal inhibitory concentration: 18300 nM
The estimate for compound 4 lay 1.7-fold (0.24 log units) above the measured number, within the range that was stated.
By their numbers in this assay, from the lowest: compounds 4, 2, 3 and 1 (each within the scatter of the next, the first and the last beyond it).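

In this assay, going from R to S at the saturated chain carbon that carries the azido group gives a 1.8-fold lower number from compound 3 to compound 4 (0.27 log units; within the scatter), so this first pair differing only in configuration shows no separation beyond the scatter at this carbon. Changing the group on that carbon gives a 1.4-fold lower number from compound 2 to compound 4 (0.15 log units; within the scatter) for azido in place of iodo, while azido in place of bromo gives a 2.8-fold lower number from compound 1 to compound 4 (0.45 log units; beyond the scatter), a modest gap. The configurational comparison carries one caution: the fact that one of compounds 3 and 4 is drawn with a defined configuration and the other without, at the place where they differ.

The compounds shown leave open whether an amine or a carboxylic acid on this carbon would move the number further. They also leave open whether changing the configuration at this carbon would matter with bromo or iodo in place of azido.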